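This account rests on a few compounds, and the source may have more. Where it says the series, first, only, none or still open, it means among the compounds named here.

Three compounds of the series carry a measurement in an assay on CHO-K1 cells for displacement of a labelled ligand from melanin-concentrating hormone receptor 1 (Homo sapiens), read by scintillation proximity assay, with a stated time of 2 h; a lower number here means a stronger inhibitor, a higher number a weaker inhibitor. Compound 1 `Cc1ccc(/C=C/C(=O)Nc2ccc3nc(N4CCC(O)(C5CC5)CC4)nc(C)c3c2)cc1` gives 344 nM, compound 2 `Cc1nc(N2CCC(N3C(=O)CCC3=O)CC2)nc2ccc(NC(=O)/C=C/c3ccc(OC(F)(F)F)cc3)cc12` gives 94 nM, and compound 3 `Cc1nc(NCCNS(C)(=O)=O)nc2ccc(NC(=O)/C=C/c3ccc(OC(F)(F)F)cc3)cc12` gives 169 nM. Compound 3 thus holds the second highest of the three numbers: its gap to compound 2 lies within the usual scatter, so no order between those two is claimed, while its gap to compound 1 lies beyond the scatter, so compound 3 is the stronger inhibitor of that pair.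

Compound 4 `Cc1nc(NCCCNS(C)(=O)=O)nc2ccc(NC(=O)/C=C/c3ccc(OC(F)(F)F)cc3)cc12` is the next member of the series, not yet measured. It differs from compound 3 in one place, ((methanesulfonamido)methyl in place of methanesulfonamido on a saturated chain carbon, two bonds along the chain from a nitrogen on an aromatic ring), and the rest of the structure is kept. Within the data shown here, no pair of measured compounds differs in this way, so there is nothing to size such a step. Without such a reference, the expected step of a 1.1-fold higher number from compound 3 to compound 4 (0.03 log units; within the scatter) is taken as small, within the scatter, in no set direction. Compound 4 is therefore expected to give about 180 nM in this assay, estimated within a range from 70 nM to 450 nM.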

Compound 4, half-maximal inhibitory concentration: 54 nM
For compound 4 the middle estimate is 3.3-fold (0.52 log units) above the measured one; measured number outside the range, below it.
By their numbers in this assay, from the lowest: compounds 4, 2 and 3 (each within the scatter of the next, the first and the last beyond it); then compound 1.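

In this assay, among these compounds, the change from (2-(methanesulfonamido)ethyl)amino to (3-(methanesulfonamido)propyl)amino gives a 3.1-fold lower number from compound 3 to compound 4 (0.50 log units; beyond the scatter) and sets the first size for a change at this position. The methanesulfonamido end is kept, and the counts of hydrogen-bond donors and acceptors, the absence of a ring and the absence of a net charge are the same on both sides, so lengthening the chain alone is enough to move the number beyond the scatter. No supporting measurement explains this step.

As far as these compounds go, whether a longer chain than 3-(methanesulfonamido)propyl lowers the number further or reverses the step remains open. Also open, from the compounds shown here alone, is how an amine or a carboxylic acid at the chain end would compare with the methanesulfonamido group at this chain length.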